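Methoxy on the fused ring of the vinyl sulfone indole

The compounds below may be only part of what the source reports. "The series", "measured", "known", "first", "only" and "open" are said of these compounds alone.

Measured compounds in the series:
compound 1 `COc1ccc(-c2[nH]c3ccccc3c2/C=C(\C#N)S(=O)(=O)c2ccccc2)cc1` with 1500 nM
compound 2 `COc1ccc2[nH]c(-c3ccccc3)c(C=C(C#N)C#N)c2c1` with 4700 nM
compound 3 `CCOC(=O)C(=Cc1c(-c2ccccc2)[nH]c2ccccc12)C(=O)OCC` with 5100 nM

In a functional assay on SN12C cells (Homo sapiens) for inhibition, read by sulforhodamine B assay, with a stated time of 48 h (on this read-out lower numbers stand for stronger inhibition of growth and higher numbers for weaker inhibition of growth), compound 1 gives the lowest number of the three measured, and its gaps to compound 2 and to compound 3 are both beyond the scatter, so on these numbers compound 1 is the most potent of the set. Within the data shown here, compound 2 and compound 3 lie close to each other; no direct step between any two measured compounds is available, as each pair differs in more than one place.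

Compound 4 `COc1ccc(-c2[nH]c3ccc(OC)cc3c2/C=C(\C#N)S(=O)(=O)c2ccccc2)cc1` is the unmeasured analogue. It differs from compound 1 in one place: methoxy in place of hydrogen on an aromatic carbon. Among the measured compounds shown here, no measured pair isolates this change, so the size of the step in this assay cannot be read from the data; the expectation is a step of no more than the usual scatter, with no clear direction. Compound 4 is estimated at 1300 nM, with a range of 500 nM to 3500 nM. The step from compound 1 to compound 4 that this estimate means is a 1.2-fold lower number from compound 1 to compound 4 (0.06 log units; within the scatter), expected to stay within the scatter.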

Compound 4, concentration for 50% growth inhibition: 2300 nM
Beside the measured number, compound 4's estimate is 1.8-fold (0.25 log units) below it; low and high end bracket the measured number.
By their numbers in this assay, from the lowest: compounds 1 and 4 (each within the scatter of the next); then compounds 2 and 3 (each within the scatter of the next).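

In this assay this aromatic carbon of the fused system now has its first direct reading: methoxy in place of hydrogen gives a 1.5-fold higher number from compound 1 to compound 4 (0.19 log units; within the scatter), so compound 1 and compound 4 cannot be told apart on this read-out. The position therefore carries methoxy, with its 2 heavy atoms and 1 hydrogen-bond acceptor, without a step that stands clear of repeat variation. Nothing available bears on why the step has this size.

A single substituent cannot show whether this carbon tolerates substitution in general, and an amine, a carboxylic acid or a longer alkoxy chain such as butoxy could give a different step here. Among these compounds, whether methoxy behaves alike with the side chains of compound 2 and compound 3 also stays open, as no pair isolates it there.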